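Adding a ring methyl in a urea series: clearance expectations

This account rests on a few compounds, and the source may have more. Where it says the series, first, only, none or still open, it means among the compounds named here.

Measured so far in an ADME assay on microsomes from liver (Mus musculus) for metabolic stability, read by LC-MS, with a stated time of 4 h, tested at 1 uM; on this read-out higher numbers stand for fast clearance and lower numbers for slow clearance:
- Compound 1, `CCOc1cc(NC(=O)NCc2cc(C)c(-c3cn(C)nc3C(F)(F)F)nn2)cc(C#N)n1`: compound 1 gives < 105 mL/min/kg in this assay, a limit of the assay and not a number.
- Compound 2, `Cc1cc(CNC(=O)Nc2cc(OCCO)nc(C(F)(F)F)c2)nnc1-c1cn(C)nc1C(F)(F)F`: compound 2 gives 102 mL/min/kg in this assay, the only plain number among the three.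
- Compound 3, `CCOc1nc(C#N)cc(NC(=O)NCc2cc(C)c(-c3cn(C)nc3C(F)(F)F)nn2)c1C`: compound 3 gives < 164 mL/min/kg in this assay, again a limit of the assay.

Compound 3 differs from compound 1 by methyl in place of hydrogen on an aromatic carbon. The step that the two limits leave unreadable from compound 1 to compound 3 cannot be read, because the limit of < 105 mL/min/kg in this assay, at which 1 of the 3 values shown sits, and the limit of < 164 mL/min/kg in this assay, at which 1 of the 3 values shown sits, are both limits rather than numbers.

Compound 4, `Cc1cc(CNC(=O)Nc2cc(C(F)(F)F)nc(OCCO)c2C)nnc1-c1cn(C)nc1C(F)(F)F`, is not yet measured. It differs from compound 2 by methyl in place of hydrogen on an aromatic carbon, the same kind of change as from compound 1 to compound 3, though the surroundings differ: in compound 4 the methyl enters ortho to a 2-hydroxyethoxy group and para to a trifluoromethyl group, whereas in compound 3 it enters ortho to an ethoxy group and para to a cyano group. How the core of compound 1 and the core of compound 2 differ is not broken down here.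

With the earlier step unreadable, the expectation for compound 4 rests on compound 2 alone, whose 102 mL/min/kg in this assay serves as the anchor. The step of a 1.0-fold lower number from compound 2 to compound 4 (0.01 log units; within the scatter) is therefore expected to be small. Compound 4 is estimated at 100 mL/min/kg in this assay, between 50 mL/min/kg and 200 mL/min/kg.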

Compound 4, clearance: 91.7 mL/min/kg
Beside the measured number, compound 4's estimate is 1.1-fold (0.04 log units) above it; the measured number falls inside the stated range.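

In this assay, methyl in place of hydrogen on an aromatic carbon, ortho to a 2-hydroxyethoxy group and para to a trifluoromethyl group, gives a 1.1-fold lower number from compound 2 to compound 4 (0.05 log units; within the scatter), so on the core of compound 2 this change leaves the two values within the scatter of each other, and this one readable pair is all the series offers. It does not show that the result carries from one core to another, because the matching step on the other core cannot be read and compound 1 stands only at a limit of the assay: the limit of < 105 mL/min/kg in this assay, at which 1 of the 4 values shown sits. Compound 3 likewise stands only at a limit of the assay: the limit of < 164 mL/min/kg in this assay, at which 1 of the 4 values shown sits.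

The compounds shown leave open whether an ethyl group or a chlorine atom on the same aromatic carbon would give a step as small as that of the methyl. They also leave open whether the methyl step would stay this small with an amine or a carboxylic acid in place of the 2-hydroxyethoxy group.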